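From iodo to bromo in a growth inhibition series

The source may report more compounds than this note shows. Statements on the series, on what has been measured and on what is new or still open speak of the compounds shown alone.

Compound 1 `Nc1ccc(-c2nc3cc(F)ccc3s2)cc1`: 11500 nM
Compound 2 `Nc1ccc(-c2nc3cc(F)ccc3s2)cc1I`: < 10 nM

In a functional assay on IGROV-1 cells (Homo sapiens) for inhibition (on this read-out lower numbers stand for stronger inhibition of growth and higher numbers for weaker inhibition of growth), compound 1 gives 11500 nM. Compound 2 gives < 10 nM, which is a limit of the assay and not a number. Compound 2 therefore sits on (the limit of < 10 nM in this assay, at which 1 of the 2 values shown sits), so its true position is not known.

Compound 3 `Nc1ccc(-c2nc3cc(F)ccc3s2)cc1Br` has bromo in place of iodo on an aromatic carbon, ortho to an amino group (bromo in place of iodo on an aromatic carbon). Within the data shown here, only one measured step bears on this change: an at least 1100-fold lower number from compound 1 to compound 2 (3.06 log units; beyond the scatter), where iodo replaced hydrogen on the same carbon. Among the measured compounds shown here, that step was large, but no measured step shows what bromo does. Compound 3 keeps a halogen at this carbon, so it is expected to stay much closer to compound 2 than to compound 1, although this is a judgement and not a measured result. A small move toward a higher number is expected, possibly within the scatter: an at least 1.2-fold higher number from compound 2 to compound 3 (0.07 log units; that floor lies within the scatter). The estimated value for compound 3 is 12 nM, with an expected range from 3 nM to 150 nM.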

Compound 3, concentration for 50% growth inhibition: < 10 nM
Compound 3 was reported as a limit; the forecaster's own chance of this, stated with the estimate: 50%; at least 1.2-fold (0.07 log units) between middle value and limit.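

The bromo compound shows that the large gain at this carbon does not depend on iodo alone, since putting bromo in place of hydrogen gives an at least 1100-fold lower number from compound 1 to compound 3 (3.06 log units; beyond the scatter) and so matches what iodo did to the same parent compound. In this assay compound 3 gives < 10 nM which is a limit of the assay and not a number. The step between the two halogens cannot be read, since the iodo and bromo compounds both rest on the same limit and the assay therefore cannot rank them: the limit of < 10 nM in this assay, at which 2 of the 3 values shown sit.

Going by these compounds, what remains open is how strong either halogen compound really is and whether iodo and bromo differ at all, as neither has a true value here. On these data alone, it is also open whether the gain belongs to halogens as a group or extends to other small substituents, and a chloro group or a methyl group on this same carbon, with the rest of the core unchanged, would help to separate those two readings.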